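The source may hold more compounds than are shown below. What is called first, only, known or untested is meant among the compounds shown, and "the series" means these compounds.

Measured in an ADME assay on Vero cells (Chlorocebus sabaeus) for cytotoxicity, read by MTT assay, with a stated time of 96 h; on this read-out lower numbers stand for higher toxicity in this test and higher numbers for lower toxicity in this test:
- compound 1 `C/C(=N\NC(N)=O)c1ccc2c(c1)nc(-c1ccccc1)n2C1CCCCC1` (> 100000 nM)
- compound 2 `COc1ccc(-c2nc3cc(/C(C)=N/NC(N)=O)ccc3n2C2CCCCC2)cc1` ("not determined" (no result reported))
- compound 3 `C/C(=N\NC(N)=O)c1ccc2c(c1)nc(-c1ccoc1)n2C1CCCCC1` ("not determined" (no result reported))

Compound 3 has no single number to stand on ("not determined" (no result reported)), and compound 2 is in the same position ("not determined" (no result reported)). Compound 4 `C/C(=N\NC(N)=O)c1ccc2c(c1)nc(-c1ccccn1)n2C1CCCCC1` carries pyridin-2-yl in place of furan-3-yl on an aromatic carbon. For the measured compounds named here, no step between measured compounds is available, and no step beyond the usual scatter, in either direction, is expected in this assay for this change. This expectation rests on compound 1 alone, and its entry (> 100000 nM) is a limit of the assay, not a number. The expected value for compound 4 is 100000 nM, with an estimated range of 40000 nM to 200000 nM for the coming measurement.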

Compound 4, half-maximal cytotoxic concentration: > 100000 nM
Compound 4: a limit, no number; the forecaster's own chance of this, stated with the estimate: 75%; the middle value lies on the limit itself.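

In this assay compound 4 gives > 100000 nM as a limit, not a number. For the compounds shown here, compound 1 also stands at a limit, so no step from compound 1 to compound 4 can be read. The compounds shown leave open whether any group at this place changes toxicity in this test.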